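The compounds below may be only part of what the source reports. "The series", "measured", "known", "first", "only" and "open" are said of these compounds alone.

In a functional assay on RD cells (Homo sapiens) for inhibition, read by luminescence and ATP content, with a stated time of 72 h (on this read-out lower numbers stand for higher toxicity in this test and higher numbers for lower toxicity in this test), the three measured compounds share one core and differ only in the group carried on the outer ring. Compound 1 `CCc1ccc(-c2ccc3ncc(-c4noc(CC)n4)cc3c2)cc1` reaches the limit of the assay, giving > 22200 nM. Compound 2 `CCc1nc(-c2cnc3ccc(-c4ccc(O)cc4)cc3c2)no1` also gives only a limit, > 2500 nM. Compound 3 `CCc1nc(-c2cnc3ccc(-c4ccc(F)cc4)cc3c2)no1` likewise gives a limit, > 7400 nM. Where compound 3 stands among these numbers cannot be said more closely, as each of the three values is a limit and not a number (the limit of > 22200 nM in this assay, at which 1 of the 3 values shown sits, (the limit of > 2500 nM in this assay, at which 1 of the 3 values shown sits), (the limit of > 7400 nM in this assay, at which 1 of the 3 values shown sits)). For the same reason the measured steps carry no size: a step that the two limits leave unreadable from compound 1 to compound 2, a step that the two limits leave unreadable from compound 1 to compound 3 and a step that the two limits leave unreadable from compound 2 to compound 3. Compound 4 `CCc1nc(-c2cnc3ccc(-c4ccc(NC(C)=O)cc4)cc3c2)no1` is not yet measured; it differs from compound 3 by acetamido in place of fluoro on an aromatic carbon. For the measured compounds named here, none of the measured steps shows how such a change moves the read-out; each of them lies between two limits. The account therefore expects no step beyond the scatter in this assay, and it is expected that compound 4 too will most likely reach only a limit. The step expected from compound 3 to compound 4 is a step that the limit leaves unreadable from compound 3 to compound 4. Compound 4 is estimated at 10000 nM, within an expected range from 3000 nM to 30000 nM.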

Compound 4, half-maximal cytotoxic concentration: > 7400 nM
Compound 4 was reported as a limit (the forecaster's own chance of this, stated with the estimate: 80%); the middle value does not contradict the limit.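

In this assay, compound 4 gives only a limit, as do compound 1, compound 2 and compound 3, so none of its steps to those three compounds can be read. The compounds shown leave open what the half-maximal cytotoxic concentration of each of the four actually is, and whether changing the group on the outer ring moves it at all.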